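Azole exchange at the chain carbon: compound 3

The source may hold more compounds than are shown below. What is called first, only, known or untested is meant among the compounds shown, and "the series" means these compounds.

Compound 1 `CCc1nccn1C[C@@]1(c2ccc(Cl)cc2Cl)OC[C@@H](COc2ccc(N3CCN(c4ccc(-n5cnn(C(C)CC)c5=O)cc4)CC3)cc2)O1` is the starting point of this comparison. For the measured compounds named here, in a functional assay on HUVEC cells (Homo sapiens), read by scintillation counting and thymidine incorporation, with a stated time of 24 h (a higher number here means a weaker inhibitor, a lower number a stronger inhibitor), compound 1 gives 224 nM, the highest of the two numbers measured so far. Going by the values given here, its only measured neighbour is compound 2 `CCC(C)n1ncn(-c2ccc(N3CCN(c4ccc(OC[C@@H]5CO[C@@](Cn6ncnn6)(c6ccc(Cl)cc6Cl)O5)cc4)CC3)cc2)c1=O`, and in this assay compound 2 gives 124 nM. Among the compounds with values here, the step of a 1.8-fold lower number from compound 1 to compound 2 (0.26 log units; within the scatter), 2H-tetrazol-2-yl in place of 2-ethyl-1H-imidazol-1-yl on a saturated chain carbon bound to a saturated ring carbon, is the one measured step that bears on the new compound.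

Compound 3 `CCC(C)n1ncn(-c2ccc(N3CCN(c4ccc(OC[C@@H]5CO[C@@](Cn6nnnc6C)(c6ccc(Cl)cc6Cl)O5)cc4)CC3)cc2)c1=O` differs from compound 1 by 5-methyl-1H-tetrazol-1-yl in place of 2-ethyl-1H-imidazol-1-yl on a saturated chain carbon bound to a saturated ring carbon. Since the comparable exchange to compound 2 stayed within the scatter, a step of similar size at most is expected here, toward a lower number or none beyond the scatter. Compound 3 is therefore estimated at 170 nM, with a range of 70 nM to 420 nM, which means an expected 1.3-fold lower number from compound 1 to compound 3 (0.12 log units; within the scatter).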

Compound 3, half-maximal inhibitory concentration: 101 nM
Beside the measured number, compound 3's estimate is 1.7-fold (0.23 log units) above it, within the range that was stated.
By their numbers in this assay, from the lowest: compounds 3, 2 and 1 (each within the scatter of the next, the first and the last beyond it).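

On the saturated chain carbon bound to a saturated ring carbon, 5-methyl-1H-tetrazol-1-yl in place of 2-ethyl-1H-imidazol-1-yl gives a 2.2-fold lower number from compound 1 to compound 3 (0.35 log units; beyond the scatter) and is a modest step, the first at this position to pass the scatter. The two tetrazolyl groups are not separated by these numbers: 5-methyl-1H-tetrazol-1-yl in place of 2H-tetrazol-2-yl gives a 1.2-fold lower number from compound 2 to compound 3 (0.09 log units; within the scatter) and leaves compound 2 and compound 3 at one level. No supporting measurement is available to explain either step.

The compounds shown leave open whether the step from compound 1 follows the azole ring itself or its alkyl group, which a 2-methyl-1H-imidazol-1-yl or a 5-ethyl-1H-tetrazol-1-yl would help to separate. As far as these compounds go, it also remains open how a 1H-1,2,4-triazol-1-yl or a non-aromatic amine such as morpholin-4-yl would read at this position.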